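Bromo for Ethyl on a Shared Core

The compounds below may be only part of what the source reports. "The series", "measured", "known", "first", "only" and "open" are said of these compounds alone.

Compound 1 `CCc1ccc(-c2nc3c(=O)n(C)c(=O)n(C)c3[nH]2)cc1`: 0.8 nM
Compound 2 `Cc1cccc(-c2nc3c(=O)n(C)c(=O)n(C)c3[nH]2)c1`: 13 nM
Compound 3 `CCCn1c(=O)c2nc(-c3ccc(Cl)cc3N)[nH]c2n(CCC)c1=O`: 0.05 nM

Of the compounds shown here, three have been measured in an assay for binding affinity to adenosine receptor A1 (Bos taurus); a higher number here means a weaker inhibitor, a lower number a stronger inhibitor. Compound 1 stands second highest of the three numbers: compound 3 gives a lower number and compound 2 a higher one, and both gaps lie beyond the usual scatter. Going by the values given here, no two measured compounds differ in only one place, so no single step can be read from the data.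

Compound 4 `Cn1c(=O)c2nc(-c3ccc(Br)cc3)[nH]c2n(C)c1=O` differs from compound 1 by bromo in place of ethyl on an aromatic carbon. Both groups are small and uncharged, so the step is expected to be modest, with compound 4 giving a slightly higher number, a step of a 2.5-fold higher number from compound 1 to compound 4 (0.40 log units; beyond the scatter) in this assay. Compound 4 is estimated at 2 nM, with a range from 0.5 nM to 8 nM.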

Compound 4, half-maximal inhibitory concentration: 0.75 nM
For compound 4 the middle estimate is 2.7-fold (0.43 log units) above the measured one; low and high end bracket the measured number.
By their numbers in this assay, from the lowest: compound 3; then compounds 4 and 1 (each within the scatter of the next); then compound 2.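

In this assay, putting bromo in place of ethyl on this aromatic carbon, para to a large group, gives a 1.1-fold lower number from compound 1 to compound 4 (0.03 log units; within the scatter). Going by these compounds alone, this is the first comparison here that changes a single place, and it shows that at this position one bromine atom and a two-carbon ethyl group cannot be told apart in this measurement. Nothing measured here explains this match.

From the compounds shown here alone, whether an amine, a carboxylic acid or a longer chain at this position would give a similar number remains open. So does whether the same swap would behave alike on the core of compound 3.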